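The source may hold more compounds than are shown below. What is called first, only, known or untested is meant among the compounds shown, and "the series" means these compounds.

In a functional assay on HCT-116 cells (Homo sapiens), read by MTT assay, with a stated time of 72 h (on this read-out higher numbers stand for weaker inhibition and lower numbers for stronger inhibition), compound 1 (`Nc1nc(N)c2c(-c3ccco3)cn([C@@H]3O[C@H](CO)[C@@H](O)[C@H]3O)c2n1`) gives > 20000 nM as a limit of the assay and not as a number. Compound 2 (`Nc1nc(N)c2c(-c3ccsc3)cn([C@@H]3O[C@H](CO)[C@@H](O)[C@H]3O)c2n1`) gives > 20000 nM in this assay and this is also a limit. Compound 3 (`Cc1nc(N)c2c(-c3ccco3)cn([C@@H]3O[C@H](CO)[C@@H](O)[C@H]3O)c2n1`) gives > 20000 nM in this assay and this too is only a limit. Compound 3 therefore has no number of its own and stands with the limit of > 20000 nM in this assay, at which 3 of the 3 values shown sit, as its only reference point.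

The change to compound 4 (`Cc1nc(N)c2c(-c3cccs3)cn([C@@H]3O[C@H](CO)[C@@H](O)[C@H]3O)c2n1`) is thiophen-2-yl in place of furan-2-yl on an aromatic carbon and it sits on an aromatic carbon of a five-membered aromatic ring with 1 nitrogen. For the measured compounds named here, two measured steps bear on it. The closer one also replaces furan-2-yl, this time with thiophen-3-yl, and it is a step that the two limits leave unreadable from compound 1 to compound 2 in size. The other puts methyl in place of amino and it is a step that the two limits leave unreadable from compound 1 to compound 3 in size. Neither step offers a size to carry over, so no step beyond the scatter can be expected with confidence and no direction can be argued. The estimated change is a step that the limit leaves unreadable from compound 3 to compound 4 in this assay on this reasoning. The estimate for compound 4 is 25000 nM with an expected range from 8000 nM to 50000 nM and the assay will most likely report only a limit again.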

Compound 4, half-maximal inhibitory concentration: > 20000 nM
Compound 4 was reported as a limit; the forecaster's own chance of this, stated with the estimate: 80%; the middle value is on the limit's open side.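

For the compounds shown here, compound 3 and compound 4 are both reported only as limits, so the change from furan-2-yl to thiophen-2-yl gives no step that can be read in this assay. The compounds shown leave open how strongly each one inhibits and whether any of these changes matters at all, as all of them share one reference point: the limit of > 20000 nM in this assay, at which 4 of the 4 values shown sit.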